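A Quinolin-2-yl Arm Weighed Against Two Measured Analogues

The source may hold more compounds than are shown below. What is called first, only, known or untested is meant among the compounds shown, and "the series" means these compounds.

compound 1 `O=C1N=C(N2CCC[C@H]2C(=O)Nc2ccc3ncnc(Nc4cccc(Cl)c4)c3c2)S/C1=C/c1cccc(Cl)c1`: 27600 nM
compound 2 `O=C1N=C(N2CCC[C@H]2C(=O)Nc2ccc3ncnc(Nc4cccc(Cl)c4)c3c2)S/C1=C/c1ccccc1Br`: 24300 nM

In a functional assay on HepG2 cells (Homo sapiens) for antiproliferative activity, read by MTT assay (on this read-out higher numbers stand for weaker inhibition and lower numbers for stronger inhibition), compound 1 gives 27600 nM and compound 2 gives 24300 nM. Among the measured compounds shown here, compound 2 holds one of only two numbers, and it does not part from compound 1: a 1.1-fold lower number from compound 1 to compound 2 (0.06 log units; within the scatter). Compound 3 `O=C1N=C(N2CCC[C@H]2C(=O)Nc2ccc3ncnc(Nc4cccc(Cl)c4)c3c2)S/C1=C/c1ccc2ccccc2n1` differs from compound 2 by quinolin-2-yl in place of 2-bromophenyl on a double-bonded chain carbon bound to a double-bonded ring carbon. For the measured compounds named here, the single measured step at this place, a 1.1-fold lower number from compound 1 to compound 2 (0.06 log units; within the scatter), stayed within the scatter, and no measured step shows a ring with a hetero atom entering there. Compound 3 is therefore expected to show a 1.2-fold lower number from compound 2 to compound 3 (0.08 log units; within the scatter), nothing beyond the scatter. Compound 3 is estimated at 20000 nM, between 7000 nM and 55000 nM.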

Compound 3, half-maximal inhibitory concentration: 22900 nM
For compound 3 the middle estimate is 1.1-fold (0.06 log units) below the measured one, and the stated range covers the measured number.
By their numbers in this assay, from the lowest: compounds 3, 2 and 1 (each within the scatter of the next).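

In this assay, quinolin-2-yl gives a 1.1-fold lower number from compound 2 to compound 3 (0.03 log units; within the scatter) and a 1.2-fold lower number from compound 1 to compound 3 (0.08 log units; within the scatter) on the double-bonded chain carbon bound to a double-bonded ring carbon. This place now holds a group with a six-membered aromatic ring with 1 hetero atom and one hydrogen-bond acceptor, and its number does not part from those of the two halogenated phenyl groups. No evidence on hand accounts for this result. Going by these compounds, whether an amine, a carboxylic acid or a longer chain here would part from these numbers stays open. The compounds shown also leave open whether any group at this place can move the number beyond the scatter.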